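A few compounds are considered here, and "the series" means these few. Any claim that something is new, unique, unknown or untested is made for them only; others in the source may bear on it.

Measured in a functional assay on HeLa cells (Homo sapiens) for inhibition, with a stated time of 72 h; a lower number here means a stronger inhibitor, a higher number a weaker inhibitor:
- compound 1 `NC1CCC(Nc2nc(NCc3ccc(Br)cc3)c3ncn(C4CCCC4)c3n2)CC1` gives 1510 nM
- compound 2 `NC1CCC(Nc2nc(NCc3ccc(-c4ccccc4)cc3)c3ncn(C4CCCC4)c3n2)CC1` gives 240 nM
- compound 3 `COc1ccccc1-c1ccc(CNc2nc(NC3CCC(N)CC3)nc3c2ncn3C2CCCC2)cc1` gives 333 nM

Compound 3 holds the middle number of the three, though the step of a 1.4-fold higher number from compound 2 to compound 3 (0.14 log units; within the scatter) shows it cannot be separated from compound 2. Both aryl compounds stand clear of the bromo compound, by a 6.3-fold lower number from compound 1 to compound 2 (0.80 log units; beyond the scatter) and by a 4.5-fold lower number from compound 1 to compound 3 (0.66 log units; beyond the scatter).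

Compound 4 `NC1CCC(Nc2nc(NCc3ccc(-c4cccc(F)c4)cc3)c3ncn(C4CCCC4)c3n2)CC1` differs from compound 3 by one change: 3-fluorophenyl in place of 2-methoxyphenyl on an aromatic carbon. For the measured compounds named here, the only measured step between two aryl groups, the added methoxy of compound 3 at 333 nM, stayed within the scatter, so no shift beyond it is expected in this assay. The expected step is a 1.2-fold lower number from compound 3 to compound 4 (0.08 log units; within the scatter). For compound 4 the estimated value is 280 nM, with an expected range of 120 nM to 650 nM.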

Compound 4, half-maximal inhibitory concentration: 445 nM
Compound 4: the middle estimate sits 1.6-fold (0.20 log units) below what was measured; the range from low to high includes it.
By their numbers in this assay, from the lowest: compounds 2, 3 and 4 (each within the scatter of the next); then compound 1.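

In this assay, a second exchange of one aryl group for another at this position, 3-fluorophenyl for 2-methoxyphenyl, also stays within the scatter (a 1.3-fold higher number from compound 3 to compound 4 (0.13 log units; within the scatter)), as does fluoro in place of hydrogen (a 1.9-fold higher number from compound 2 to compound 4 (0.27 log units; within the scatter)). The advantage over bromo holds for this third aryl group (a 3.4-fold lower number from compound 1 to compound 4 (0.53 log units; beyond the scatter)), so all three aryl compounds stand clear of compound 1. Nothing available explains these steps.

The exchange alters both the substituent and its place on the phenyl ring, so neither can be read alone. Going by these compounds, how an amine or a carboxylic acid on that ring would fare remains open.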